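Replacing the methoxyphenyl with pyridin-4-yl on the shared core

The compounds below may be only part of what the source reports. "The series", "measured", "known", "first", "only" and "open" are said of these compounds alone.

Compound 1 `CCOC(=O)c1c(N)sc(/N=C/c2ccccc2)c1C(=O)OCC`: 31200 nM
Compound 2 `CCOC(=O)c1c(N)sc(/N=C/c2ccc(N(C)C)cc2)c1C(=O)OCC`: 131000 nM
Compound 3 `CCOC(=O)c1c(N)sc(/N=C/c2ccc(OC)cc2)c1C(=O)OCC`: 189000 nM

In a functional assay on HeLa cells (Homo sapiens) for inhibition, read by MTT assay, with a stated time of 48 h (on this read-out higher numbers stand for weaker inhibition and lower numbers for stronger inhibition), compound 3 gives the highest number of the three, with compound 2 nearest and compound 1 furthest away. Compound 4 `CCOC(=O)c1c(N)sc(/N=C/c2ccncc2)c1C(=O)OCC` differs from compound 3 by pyridin-4-yl in place of 4-methoxyphenyl on a carbon with a double bond to nitrogen. Within the data shown here, no measured step covers this exact change. The nearest guides are a 6.1-fold higher number from compound 1 to compound 3 (0.78 log units; beyond the scatter), which shows that removing the methoxy lowers the number, and a 1.4-fold higher number from compound 2 to compound 3 (0.16 log units; within the scatter), which shows two different groups at that aromatic carbon giving similar numbers. Compound 4 also loses the methoxy but gains a ring nitrogen, so the number is expected to fall modestly, a 3.2-fold lower number from compound 3 to compound 4 (0.50 log units; beyond the scatter). Compound 4 is therefore estimated at 60000 nM in this assay, within 18000 nM to 200000 nM.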

Compound 4, half-maximal inhibitory concentration: 35400 nM
For compound 4 the middle estimate is 1.7-fold (0.23 log units) above the measured one, and the stated range covers the measured number.
By their numbers in this assay, from the lowest: compounds 1 and 4 (each within the scatter of the next); then compounds 2 and 3 (each within the scatter of the next).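

In this assay, pyridin-4-yl in place of 4-methoxyphenyl gives a 5.3-fold lower number from compound 3 to compound 4 (0.73 log units; beyond the scatter), and in place of 4-(dimethylamino)phenyl it gives a 3.7-fold lower number from compound 2 to compound 4 (0.57 log units; beyond the scatter). Against plain phenyl, the ring nitrogen makes no clear difference, with a 1.1-fold higher number from compound 1 to compound 4 (0.05 log units; within the scatter), so this position accepts a ring nitrogen without the weaker inhibition seen with the two substituted phenyl rings. Nothing measured here explains these differences.

Left open is how a phenyl ring carrying a carboxylic acid or a chlorine would compare at this place. Also open, as far as these compounds go, is whether a saturated ring such as piperidine, or a longer chain, would be accepted there.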